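Trimming the acyl group on the pyrazoline amide

The compounds below may be only part of what the source reports. "The series", "measured", "known", "first", "only" and "open" are said of these compounds alone.

Compound 2 `O=C(C1CCCCC1)N1N=CCC1c1ccccc1` stands highest of the three numbers in a physicochemical assay for lipophilicity, read by HPLC, measured as chromatographic lipophilicity, at pH 7.4 (on this read-out lower numbers stand for lower lipophilicity and higher numbers for higher lipophilicity), at 5.9; compound 1 `O=C(C1CCN(c2ccncn2)CC1)N1N=CC[C@H]1c1ccccc1` gives 3.2 and compound 3 `CC(=O)N1CCC(C(=O)N2N=CC[C@H]2c2ccccc2)CC1` gives 2.5. Among the compounds with values here, the one measured step, a number 0.70 log units lower from compound 1 to compound 3 (beyond the scatter), concerns the amine nitrogen in a ring and does not touch the carbonyl side, so no measured step bears directly on the present change. Compound 4 `CC(C)C(=O)N1N=CCC1c1ccccc1` differs from compound 2 by isopropyl in place of cyclohexyl on a carbonyl carbon. Removing the six-membered ring and leaving a three-carbon chain is expected to lower the read-out in this assay by more than the scatter, so a step of a number 1.40 log units lower from compound 2 to compound 4 (beyond the scatter) is estimated. Compound 4 is therefore expected at 4.5, with a range from 3.8 to 5.2.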

Compound 4, distribution coefficient: 4.4
The estimate for compound 4 lay 0.10 log units above the measured number; the measured number falls inside the stated range.
By their numbers in this assay, from the lowest: compound 3; then compound 1; then compound 4; then compound 2.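

Within the data shown here, the group on the carbonyl carbon clearly moves the read-out in this assay: a number 1.50 log units lower from compound 2 to compound 4 (beyond the scatter) is a large step, whereas the only earlier step, a number 0.70 log units lower from compound 1 to compound 3 (beyond the scatter), was modest and sat on the amine nitrogen in a ring. Among these compounds, this is the first measured change on the carbonyl side of the amide. No supporting measurement accounts for the size of this step.

With only cyclohexyl and isopropyl compared here, the ring and the carbon count cannot be separated. A cyclopropyl group, a straight propyl chain or a carbonyl substituent carrying an amine would help to tell them apart.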